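The source may hold more compounds than are shown below. What is called first, only, known or untested is meant among the compounds shown, and "the series" means these compounds.

Measured so far:
compound 1, `CC1(C)Oc2ccc(C#N)cc2[C@@H](/N=C(\NC#N)Sc2ccccc2)[C@@H]1O`: 4900 nM
compound 2, `C/N=C(\NC#N)N[C@@H]1c2cc(C#N)ccc2OC(C)(C)[C@H]1O`: 200 nM
compound 3, `COC(=O)c1cn([C@@H]2c3cc(C#N)ccc3OC(C)(C)[C@H]2O)c2ccccc12`: 500 nM

All three were tested in a functional assay (aorta) with Rattus norvegicus as the target; on this read-out lower numbers stand for stronger inhibition and higher numbers for weaker inhibition. Compound 1 stands at the highest number of the three: its gap to compound 3, and its larger gap to compound 2, both lie beyond the usual scatter of this assay, so compound 1 is the weakest inhibitor among the measured compounds. Compound 2 and compound 3 share the same core as compound 1 and reach clearly lower numbers.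

Compound 4, `CC1(C)Oc2ccc(C#N)cc2[C@@H](/N=C(\NC#N)Nc2ccc(C(=O)O)cc2)[C@@H]1O`, has not yet been measured. It differs from compound 1 in one place: (4-carboxyphenyl)amino in place of phenylsulfanyl on a carbon with a double bond to nitrogen. Compound 2, which holds the lowest number, also carries an amino group rather than a phenylsulfanyl group on the carbon with a double bond to nitrogen, which is the only hint in hand about this kind of change. Among the compounds with values here, no pair of compounds in these data isolates the change itself, so the expectation rests on that hint alone.

For compound 4 the step of a 4.1-fold lower number from compound 1 to compound 4 (0.61 log units; beyond the scatter) is expected to go downward, beyond the scatter, toward stronger inhibition. Compound 4 is estimated at 1200 nM, within a range from 300 nM to 5000 nM.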

Compound 4, half-maximal inhibitory concentration: > 100000 nM
Compound 4: no number, only a limit; the forecaster's own chance of this, stated with the estimate: 10%; at least 83-fold (1.92 log units) between middle value and limit.
By their numbers in this assay, from the lowest: compound 2; then compound 3; then compound 1. At a limit, above all of these: compound 4.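

In this assay, compound 4 gives no number but only a limit of the assay: the limit of > 100000 nM in this assay, at which 1 of the 4 values shown sits.

Placing (4-carboxyphenyl)amino in place of phenylsulfanyl on a carbon with a double bond to nitrogen gives an at least 20-fold higher number from compound 1 to compound 4 (1.30 log units; beyond the scatter), the first step in this set between compounds that differ in one place, and it is large and runs toward weaker inhibition. This shows that this position is far from indifferent to what sits on it, and that an amino group there does not by itself go with a low number: compound 2 and compound 4 both carry one, yet they lie at opposite ends of the series.

From the compounds shown here alone, what stays open is which part of the change goes with the step, since the nitrogen in place of sulfur and the carboxylic acid on the ring enter together. A plain phenylamino group in this place, or a methyl ester in place of the carboxylic acid, would tell these two parts apart.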